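A few compounds are considered here, and "the series" means these few. Any claim that something is new, unique, unknown or untested is made for them only; others in the source may bear on it.

Measured in a functional assay on B16 cells (Mus musculus) for cytotoxicity, read by MTT assay, with a stated time of 72 h; a higher number here means a weaker inhibitor, a lower number a stronger inhibitor:
compound 1 , `CN1CCN(CCCCOc2c(OCc3ccccc3)cc(O)c3c(=O)cc(-c4ccccc4)oc23)CC1`, gives 2370 nM
compound 2 , `CN1CCN(CCCCOc2c(OCc3ccc(C#N)cc3)cc(O)c3c(=O)cc(-c4ccccc4)oc23)CC1`, gives 3700 nM
compound 3 , `CN1CCN(CCCCOc2c(OCc3ccco3)cc(O)c3c(=O)cc(-c4ccccc4)oc23)CC1`, gives 3530 nM

Compound 3 holds the second highest of the three numbers, and all three lie within the scatter of one another: a 1.5-fold higher number from compound 1 to compound 3 (0.17 log units; within the scatter) and a 1.0-fold lower number from compound 2 to compound 3 (0.02 log units; within the scatter), so no order among compounds 1, 2 and 3 can be read from these values.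

Compound 4, `CN1CCN(CCCCOc2c(OCc3nc4ccccc4o3)cc(O)c3c(=O)cc(-c4ccccc4)oc23)CC1`, is not yet measured in this assay. It differs from compound 3 in one place: 1,3-benzoxazol-2-yl in place of furan-2-yl on a saturated chain carbon bound to an oxygen on an aromatic ring.

Among the compounds with values here, two measured steps bear on this position, the group carried on the saturated chain carbon bound to an oxygen on the aromatic ring: a 1.5-fold higher number from compound 1 to compound 3 (0.17 log units; within the scatter) and a 1.0-fold lower number from compound 2 to compound 3 (0.02 log units; within the scatter). Both exchange that aromatic group and both stay within the scatter. Nothing here measures a bicyclic group at this place, so the step from furan-2-yl to 1,3-benzoxazol-2-yl rests on an extrapolation with a wide range. On what is known, no step beyond the scatter is expected, a 1.0-fold lower number from compound 3 to compound 4 (0.00 log units; within the scatter). Compound 4 is estimated at 3500 nM in this assay, within a range from 1200 nM to 10000 nM.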

Compound 4, half-maximal inhibitory concentration: 2080 nM
Estimate against measurement, compound 4: 1.7-fold (0.23 log units) above; the range from low to high includes it.
By their numbers in this assay, from the lowest: compounds 4, 1, 3 and 2 (each within the scatter of the next).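

In this assay, this is the first bicyclic group at the saturated chain carbon bound to an oxygen on an aromatic ring, and it stays within the scatter of all three monocyclic groups shown (a 1.7-fold lower number from compound 3 to compound 4 (0.23 log units; within the scatter); a 1.8-fold lower number from compound 2 to compound 4 (0.25 log units; within the scatter); a 1.1-fold lower number from compound 1 to compound 4 (0.06 log units; within the scatter)). Adding a fused six-membered aromatic ring of carbon only and a ring nitrogen to the five-membered ring therefore leaves the number unresolved from those of the phenyl, 4-cyanophenyl and furan-2-yl compounds, so the four aromatic groups shown cannot be ranked at this place. No measurement bears on why the values stay so close together.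

Still open, on these data alone, is whether a carboxylic acid or a primary amine in place of the aromatic group, or a longer chain between the ring oxygen and that aromatic group, would give a step beyond the scatter. The compounds shown also all share the same core and the same methylpiperazine side chain, so it remains open whether this flat picture would hold with a morpholine in place of that methylpiperazine.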